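Swapping Fluoro for Chloro on the Shared Core

This account rests on a few compounds, and the source may have more. Where it says the series, first, only, none or still open, it means among the compounds named here.

Compound 1 (`CCn1cc(C(=O)O)c(=O)c2cc(F)c(N3CCN(CN4C(=O)/C(=N\NC(=S)NO)c5cc(C)ccc54)CC3)cc21`) gives 327000 nM in this study
Compound 2 (`CCn1cc(C(=O)O)c(=O)c2cc(F)c(N3CCN(CN4C(=O)/C(=N\NC(=S)NO)c5cc(F)ccc54)CC3)cc21`) gives 208000 nM in this study

Both numbers come from an ADME assay on MT4 cells (Homo sapiens) for cytotoxicity, read by spectrophotometry, with a stated time of 5 days (on this read-out lower numbers stand for higher toxicity in this test and higher numbers for lower toxicity in this test), and they lie within the usual scatter of each other. Within the data shown here, compound 2 therefore cannot be ranked against compound 1, the only other compound measured. Compound 3 (`CCn1cc(C(=O)O)c(=O)c2cc(F)c(N3CCN(CN4C(=O)/C(=N\NC(=S)NO)c5cc(Cl)ccc54)CC3)cc21`) has not yet been measured. It differs from compound 2 in a single group (chloro in place of fluoro on an aromatic carbon) with chloro in place of fluoro on an aromatic carbon, and the rest of the molecule stays the same.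

Among the measured compounds shown here, only one measured step bears on this change. It is a 1.6-fold lower number from compound 1 to compound 2 (0.20 log units; within the scatter) with fluoro in place of methyl on an aromatic carbon, and that step stays within the scatter. For the measured compounds named here, no measured compound yet carries chloro, so this single step is only a modest guide. In this assay no step beyond the scatter is expected, in either direction. The estimate is a 1.1-fold higher number from compound 2 to compound 3 (0.02 log units; within the scatter) and so no real change. The expected value for compound 3 is 220000 nM (range 120000 nM to 390000 nM).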

Compound 3, half-maximal cytotoxic concentration: 186000 nM
Beside the measured number, compound 3's estimate is 1.2-fold (0.07 log units) above it; the measured number falls inside the stated range.
By their numbers in this assay, from the lowest: compounds 3, 2 and 1 (each within the scatter of the next).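

In this assay, the change to chloro on this aromatic carbon gives a 1.1-fold lower number from compound 2 to compound 3 (0.05 log units; within the scatter) and, set against the methyl compound, a 1.8-fold lower number from compound 1 to compound 3 (0.25 log units; within the scatter) with both steps within the usual scatter. The earlier pair could speak only to methyl and fluoro, whereas a third group now stands at the same place and two further direct comparisons can be read. Methyl, fluoro and chloro therefore cannot be told apart here, so across these three compounds the identity of this single-group substituent shows no readable effect on the cytotoxicity number, and no measurement on hand speaks to why the three values sit so close together.

From the compounds shown here alone, all three groups tested at this place are small, so it remains open whether an amine, a carboxylic acid or a longer chain such as butoxy would also stay within the scatter. The compounds also leave open whether changes elsewhere on the shared core, which is identical across all three, would move the number in a way that could be read.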